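The compounds below may be only part of what the source reports. "The series", "measured", "known", "first", "only" and "open" are said of these compounds alone.

Measured in a functional assay on NCI-H23 cells (Homo sapiens) for antiproliferative activity, read by sulforhodamine B assay; on this read-out higher numbers stand for weaker inhibition of growth and lower numbers for stronger inhibition of growth:
compound 1 `CCCCCCOc1cccc(O)c1C(=O)/C=C/c1ccc(O)cc1`: > 30000 nM, a limit of the assay and not a number
compound 2 `CC(C)(C)CCOc1cccc(O)c1C(=O)/C=C/c1ccc(O)cc1`: 3130 nM
compound 3 `CCC(CC)COc1cccc(O)c1C(=O)/C=C/c1ccc(O)cc1`: 3210 nM

Compound 3, at 3210 nM, stands level with compound 2, as a 1.0-fold higher number from compound 2 to compound 3 (0.01 log units; within the scatter) shows. The next compound, compound 4 `O=C(/C=C/c1ccc(O)cc1)c1c(O)cccc1OCc1ccccc1`, has phenyl in place of pentan-3-yl on a saturated chain carbon bound to an oxygen on an aromatic ring.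

Among the compounds with values here, three measured steps bear on this change. Two replace an unbranched chain end with a branched one, and both lie beyond the scatter: an at least 9.5-fold lower number from compound 1 to compound 2 (0.98 log units; beyond the scatter) and an at least 9.3-fold lower number from compound 1 to compound 3 (0.97 log units; beyond the scatter). The third swaps one branched group for another and stays within the scatter: a 1.0-fold higher number from compound 2 to compound 3 (0.01 log units; within the scatter). Within the data shown here, compound 4 is closest to that third case, since its group also replaces a branched one, but no measured step puts a ring at this place, so the uncertainty is wide.

The estimate means a 1.2-fold higher number from compound 3 to compound 4 (0.10 log units; within the scatter), an expected step no larger than the scatter. For compound 4 the expected value is 4000 nM, with an estimated range of 1300 nM to 15000 nM.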

Compound 4, concentration for 50% growth inhibition: > 30000 nM
Compound 4: only a limit was reported; the forecaster's own chance of this, stated with the estimate: 15%; middle value at least 7.5-fold (0.87 log units) from the limit.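

In this assay compound 4 gives > 30000 nM, a limit of the assay and not a number. The earlier compounds shown here showed one branched group standing in for another without a readable change, but phenyl on this saturated chain carbon does not behave like those branched groups, with an at least 9.3-fold higher number from compound 3 to compound 4 (0.97 log units; beyond the scatter) and an at least 9.5-fold higher number from compound 2 to compound 4 (0.98 log units; beyond the scatter). So a branched end on the chain is linked to measurable growth inhibition here, while this aromatic ring is not, and the step to compound 1 cannot be read because both compounds sit at the same limit: the limit of > 30000 nM in this assay, at which 2 of the 4 values shown sit.

The compounds shown leave open whether the drop goes with an aromatic ring specifically or with any ring, which cyclohexyl at this place would test. They also leave open whether phenylethyl in place of benzyl would give the same result.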